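The source may report more compounds than this note shows. Statements on the series, on what has been measured and on what is new or still open speak of the compounds shown alone.

Working notes on the series. In an assay on MCF7 cells for inhibition of Steryl-sulfatase (Homo sapiens), read by scintillation counting, with a stated time of 5 h, tested at 0.1 uM (on this read-out lower numbers stand for a weaker effect and higher numbers for a stronger effect at the one concentration tested), compound 1 `CCC(CC)(c1ccc(OS(N)(=O)=O)c(C)c1)c1ccc(OS(N)(=O)=O)c(C)c1` reaches only the limit of the assay, < 10%. Compound 2 `C[Si](C)(c1ccc(O)cc1)c1ccc(O)cc1` likewise sits at the limit of the assay in this assay, < 10%. Both shown values therefore stand at the same point, as the limit of < 10% in this assay, at which 2 of the 2 values shown sit, records, so nothing can be said of any order between compound 1 and compound 2 beyond the scatter.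

Compound 3 `C[Si](C)(c1ccc(O)cc1)c1ccc(OS(N)(=O)=O)cc1` has not been measured. It differs from compound 2 in one place: sulfamoyl in place of hydrogen on an oxygen on an aromatic ring. Going by the values given here, no measured pair with this change exists here, so the step from compound 2 to compound 3 can only be expected, not read off. Given that compound 1, which carries the sulfamoyl group twice, also stands at < 10%, only a small step is expected, a number at least 5 percentage points higher from compound 2 to compound 3 (that floor lies within the scatter), most likely within the scatter and possibly leaving compound 3 at the limit as well. The estimate for compound 3 in this assay is 15%, between 0% and 40%.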

Compound 3, a percentage reported as inhibition, at one concentration (the size of the read-out at that concentration, not a potency): 25.2%
Compound 3: the middle estimate sits 10.2 percentage points below what was measured; measured number inside the range.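

In this assay, going by these compounds alone, the change from hydroxy to sulfamoyloxy gives a number at least 15.2 percentage points higher from compound 2 to compound 3 (beyond the scatter), the first step that can be read at all. A single change on the shared core is thus enough to bring compound 3 to 25.2%. The true size of the step remains unknown, and only its lower bound can be given, since the starting value of compound 2 is a limit and not a number: the limit of < 10% in this assay, at which 2 of the 3 values shown sit.

Compound 1 differs from compound 3 in more than one place, so the two cannot be compared and the sulfamoyl effect in compound 1 stays unresolved. As far as these compounds go, it also remains open whether a smaller group on this oxygen, such as methyl or acetyl, would give any such step, or whether sulfamoyl on the remaining hydroxy of compound 3 would add to it.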